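The source may hold more compounds than are shown below. What is called first, only, known or untested is meant among the compounds shown, and "the series" means these compounds.

Compound 1 `OC1CCCC(c2n[nH]cc2-c2ccnc(NC3CCCC3)n2)C1`: 0.015 mL/min/kg
Compound 2 `CC(C)Nc1nccc(-c2c[nH]nc2C2CCCOC2)n1`: 0.034 mL/min/kg
Compound 3 `CC(C)Nc1nccc(-c2c[nH]nc2-c2ccc(Cl)cc2)n1`: 0.106 mL/min/kg

In an in vitro ADME assay on microsomes from liver (Homo sapiens) for metabolic stability (a lower number here means slower removal, a higher number faster removal of the compound), compound 2 gives 0.034 mL/min/kg, the middle of the three numbers. Compound 1 lies lower and compound 3 higher, both beyond the usual scatter.

Compound 4 `c1cc(-c2c[nH]nc2C2CCCOC2)nc(NC2CCCC2)n1` has not been measured yet. It differs from compound 2 in one place: cyclopentyl in place of isopropyl on a nitrogen on an aromatic ring. In short, cyclopentyl takes the place of isopropyl on a nitrogen on an aromatic ring.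

Among the measured compounds shown here, only one measured step is available, a 3.1-fold higher number from compound 2 to compound 3 (0.49 log units; beyond the scatter). That modest step comes from a change at a different place, so it gives a sense of size but no direction. The nearest hint is compound 1 at 0.015 mL/min/kg, which also carries cyclopentylamino but differs elsewhere as well, so its value cannot isolate this change.

A small change is therefore expected, no larger than the scatter. The estimated step is a 1.2-fold higher number from compound 2 to compound 4 (0.07 log units; within the scatter). For compound 4 the expected value is 0.04 mL/min/kg, with an estimated range of 0.015 mL/min/kg to 0.1 mL/min/kg.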

Compound 4, clearance: 0.089 mL/min/kg
Compound 4: middle estimate off by 2.2-fold (0.35 log units), on the low side, and the stated range covers the measured number.
By their numbers in this assay, from the lowest: compound 1; then compound 2; then compounds 4 and 3 (each within the scatter of the next).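

In this assay the swap of isopropyl for cyclopentyl on this nitrogen gives a 2.6-fold higher number from compound 2 to compound 4 (0.42 log units; beyond the scatter), which shows that the group at this position can move the number beyond the scatter. With cyclopentylamino held constant, oxan-3-yl in place of 3-hydroxycyclohexyl on an aromatic carbon gives a 5.9-fold higher number from compound 1 to compound 4 (0.77 log units; beyond the scatter), so the group at that other place also matters. Cyclopentylamino therefore does not bring a low number by itself, as compound 1 and compound 4 both carry it and still differ beyond the scatter.

Nothing shown gives a reason for either step. From the compounds shown here alone, it remains open how cyclopropyl or a longer chain on this nitrogen would compare, and whether the isopropyl-to-cyclopentyl step keeps its size with 4-chlorophenyl or 3-hydroxycyclohexyl on the aromatic carbon.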